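This account rests on a few compounds, and the source may have more. Where it says the series, first, only, none or still open, it means among the compounds named here.

In an ADME assay on the whole organism (Rattus norvegicus, strain Sprague-Dawley) for pharmacokinetics, using cassette dosing, at a dose of 1 mg/kg by the oral route (on this read-out lower numbers stand for lower oral bioavailability and higher numbers for higher oral bioavailability), the measured compounds are:
Compound 1 `O=C(Nc1ccc2[nH]c(=O)oc2c1)C(=O)N1CCN(c2ccc(Cl)cc2)CC1`: 17.8%
Compound 2 `O=C(Nc1ccc2[nH]c(=O)oc2c1)C(=O)N1CCN(c2ccc(F)cc2)CC1`: 39.3%
Compound 3 `O=C(Nc1ccc2[nH]c(=O)oc2c1)C(=O)N1CCN(c2ccc(F)c(F)c2)CC1`: 13%

The starting point is compound 3, at 13%. The data show a number 4.8 percentage points lower from compound 1 to compound 3 (within the scatter), and they also show a number 26.3 percentage points lower from compound 2 to compound 3 (beyond the scatter). Two of the three compounds therefore sit low together, and one sits clear of them.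

Compound 4 `O=C(Nc1ccc2[nH]c(=O)oc2c1)C(=O)N1CCN(c2ccc(C(F)(F)F)c(F)c2)CC1` keeps the shared core and changes one group: trifluoromethyl in place of fluoro on an aromatic carbon, para to a large group and ortho to a fluoro group (trifluoromethyl in place of fluoro on an aromatic carbon).

Among the measured compounds shown here, no measured step makes this exact exchange, so the guides are indirect. On the carbon para to the large group, the exchange of chloro for fluoro gave a number 21.5 percentage points higher from compound 1 to compound 2 (beyond the scatter), a modest step, so a change there can register. The fluoro that compound 4 keeps appeared in a number 26.3 percentage points lower from compound 2 to compound 3 (beyond the scatter), also modest. With that fluoro already present, and with only compound 2 standing high, no clear rise is expected. The expected outcome is no step beyond the scatter, and the estimate is a number 1 percentage points higher from compound 3 to compound 4 (within the scatter). For compound 4 the expected value is 14%, with an estimated range from 3% to 32%.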

Compound 4, oral bioavailability: 8.7%
Compound 4: the middle estimate sits 5.3 percentage points above what was measured; the range from low to high includes it.
By their numbers in this assay, from the lowest: compounds 4, 3 and 1 (each within the scatter of the next); then compound 2.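

In this assay, replacing fluoro with trifluoromethyl on the aromatic carbon para to a large group and ortho to a fluoro group gives a number 4.3 percentage points lower from compound 3 to compound 4 (within the scatter). The earlier compounds shown here showed only single halogen atoms on this carbon, whereas this exchange puts a group of four heavy atoms there in place of one, and the read-out does not separate the two compounds. With the ortho fluoro group present, then, this position has so far shown no response to the larger group, and nothing available explains this result.

The compounds shown leave open how trifluoromethyl would behave on this carbon without that fluoro group, the setting in which compound 2, carrying fluoro alone, gives 39.3%. As far as these compounds go, it also remains open whether a nitrile or a methoxy group on the same carbon would move the oral bioavailability clearly away from the low values of compound 3 and compound 4.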